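The compounds below may be only part of what the source reports. "The series", "measured", "known", "first", "only" and "open" are said of these compounds alone.

Compound 1 `O=c1cc(CSC(=S)N2CCCC2)oc2ccccc12` was tested in a functional assay on MDA-MB-435S cells (Homo sapiens) for antiproliferative activity, read by MTT assay, with a stated time of 72 h; a higher number here means a weaker inhibitor, a lower number a stronger inhibitor. In this assay compound 1 gives only a limit of the assay, > 30000 nM, and no number. Compound 2 `O=c1cc(CSC(=S)N2CCCCC2)oc2ccccc12` likewise gives only a limit in this assay, > 25000 nM. The step that the two limits leave unreadable from compound 1 to compound 2 therefore cannot be read, as the two limits the limit of > 25000 nM in this assay, at which 1 of the 2 values shown sits, and the limit of > 30000 nM in this assay, at which 1 of the 2 values shown sits, hide its size. Compound 3 `O=c1c(Cl)c(CSC(=S)N2CCCC2)oc2ccccc12` differs from compound 1 by chloro in place of hydrogen on an aromatic carbon. Going by the values given here, no measured step bears on this change, so no shift beyond the scatter can be foreseen, and compound 3 is expected to give about 30000 nM in this assay, within 8000 nM to 100000 nM, an expected step of a number no higher from compound 1 to compound 3 (the limit leaves the size open).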

Compound 3, half-maximal inhibitory concentration: 1800 nM
Beside the measured number, compound 3's estimate is 17-fold (1.22 log units) above it; measured number outside the range, below it.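

Going by these compounds alone, the first readable step in this assay is an at least 16-fold lower number from compound 1 to compound 3 (1.22 log units; beyond the scatter) for chloro in place of hydrogen on an aromatic carbon, two atoms from the ring oxygen. This position therefore responds strongly to a single added atom, whereas the step between the two earlier compounds cannot be read, since both give only limits. Nothing measured here explains this shift. From the compounds shown here alone, whether the gain is specific to chloro stays open, and fluoro, methyl or methoxy at this position would test that. Also open, going by these compounds, is whether chloro acts likewise with the piperidin-1-yl group of compound 2.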